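Methyl in place of chloro: compound 2 to compound 3

This account rests on a few compounds, and the source may have more. Where it says the series, first, only, none or still open, it means among the compounds named here.

Compound 1 `COc1ccc(CN(C(=O)CSC(=S)N2CCc3cc(OC)ccc32)c2cc(OC)c(OC)c(OC)c2)cc1` has a measured value in a functional assay on HCT-116 cells (Homo sapiens) for inhibition, read by CCK-8 assay, with a stated time of 48 h (on this read-out lower numbers stand for stronger inhibition and higher numbers for weaker inhibition), of 9810 nM. Compound 2 `COc1ccc(CN(C(=O)CSC(=S)N2CCN(C(=O)OC(C)(C)C)CC2)c2ccc(Cl)cc2)cc1` gives > 20000 nM in this assay, which is a limit of the assay and not a number. Compound 2 therefore stands at the limit of > 20000 nM in this assay, at which 1 of the 2 values shown sits. Compound 3 `COc1ccc(CN(C(=O)CSC(=S)N2CCN(C(=O)OC(C)(C)C)CC2)c2ccc(C)cc2)cc1` differs from compound 2 by methyl in place of chloro on an aromatic carbon. Among the compounds with values here, no step between measured compounds is available, so neither size nor direction is known for this change. The step that the limit leaves unreadable from compound 2 to compound 3 is expected to stay within the scatter, with a limit again likely. Compound 3 is estimated at 25000 nM, between 10000 nM and 60000 nM.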

Compound 3, half-maximal inhibitory concentration: > 20000 nM
Compound 3 was reported as a limit (the forecaster's own chance of this, stated with the estimate: 75%); the middle value does not contradict the limit.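

Compound 2 and compound 3 both stand as limits of the assay in this assay and no step can be read between them. As far as these compounds go, the size and direction of methyl in place of chloro on an aromatic carbon remain open.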